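The compounds below may be only part of what the source reports. "The series", "measured", "known", "first", "only" and "open" are said of these compounds alone.

Going by the values given here, compound 2, with structure `CC(C)(N)C(=O)N[C@H](COCc1ccccc1)c1nnnn1CC#N`, gives the higher of the two numbers so far: in an assay on isolated protein for displacement of a labelled ligand from growth hormone secretagogue receptor type 1 (Homo sapiens), with a stated time of 1 h (on this read-out higher numbers stand for weaker inhibition and lower numbers for stronger inhibition), compound 2 gives 4170 nM. Among the compounds with values here, the only neighbour on record is compound 1, `COC(=O)C(c1ccccc1)n1nnnc1[C@@H](COCc1ccccc1)NC(=O)C(C)(C)N`, and in this assay compound 1 gives 470 nM. Within the data shown here, the one step between them, an 8.9-fold higher number from compound 1 to compound 2 (0.95 log units; beyond the scatter), is the only measured step that bears on what follows.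

Compound 3, `COC(=O)CCCn1nnnc1[C@@H](COCc1ccccc1)NC(=O)C(C)(C)N`, differs from compound 2 by 2-(methoxycarbonyl)ethyl in place of cyano on a saturated chain carbon bound to an aromatic nitrogen. This brings an ester-bearing chain back onto the aromatic nitrogen, as in compound 1, though without the phenyl that compound 1 carries on that chain. The step from compound 1 to compound 2 removed a methoxycarbonyl together with a phenyl and weakened binding beyond the scatter; the present step restores a methoxycarbonyl alone. Partial recovery of the number is therefore expected, but a single measured step is a thin basis, and the estimate for compound 3 is a 2.8-fold lower number from compound 2 to compound 3 (0.44 log units; beyond the scatter), placing it at 1500 nM with a range from 400 nM to 5000 nM.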

Compound 3, inhibition constant: 2380 nM
Compound 3: the middle estimate sits 1.6-fold (0.20 log units) below what was measured, and the stated range covers the measured number.
By their numbers in this assay, from the lowest: compound 1; then compounds 3 and 2 (each within the scatter of the next).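

Putting 2-(methoxycarbonyl)ethyl in place of cyano on a saturated chain carbon bound to an aromatic nitrogen gives a 1.8-fold lower number from compound 2 to compound 3 (0.24 log units; within the scatter) in this assay, so at this place the longer ester chain and the small nitrile cannot be told apart, even though the entering group is clearly larger by its count of heavy atoms. The other step, a 5.1-fold higher number from compound 1 to compound 3 (0.70 log units; beyond the scatter), shows something a single step could not: compound 1 and compound 3 both carry a methoxycarbonyl, yet compound 1 stays apart from compound 3 beyond the scatter, so the ester alone does not reproduce the number of compound 1. No independent measurement is available to explain any of these numbers.

Compound 1 and compound 3 differ both in the phenyl and in how the ester is held on the chain, so the compounds shown cannot say which of these two features matters. A plain benzyl on the aromatic nitrogen, or a phenyl-bearing chain with a carboxylic acid in place of the methyl ester, would help to separate them.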